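Aryl Swap on a Pyridine Glucagon Antagonist Scaffold

The source may hold more compounds than are shown below. What is called first, only, known or untested is meant among the compounds shown, and "the series" means these compounds.

Measured so far:
compound 1, `CCCCCc1c(C(C)C)nc(C(C)C)c(CO)c1-c1cccc(Cl)c1`: 49%
compound 2, `CCCCCc1c(C(C)C)nc(C(C)C)c(CO)c1-c1cccc(C(F)(F)F)c1`: 25%

Of the compounds shown here, two sharing one core have been tested in an assay on CHO cells for inhibition of Glucagon receptor (Homo sapiens), tested at 20 uM; a lower number here means less inhibition, a higher number more inhibition at the concentration tested (going by the name of the read-out). Compound 1 gives 49% and stands highest of the two numbers; its nearest neighbour is compound 2, which gives 25%. For the measured compounds named here, the one measured step, a number 24 percentage points lower from compound 1 to compound 2 (beyond the scatter), is a trifluoromethyl in place of chloro on an aromatic carbon, a modest drop that lies beyond the scatter.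

The next compound, compound 3, `CCCCCc1c(C(C)C)nc(C(C)C)c(CO)c1-c1ccccc1C`, has not yet been measured. Its change from compound 1 is 2-methylphenyl in place of 3-chlorophenyl on an aromatic carbon. Going by the values given here, no measured step covers this change: the only step available swaps one group on the 3-position of the phenyl for another, whereas here the whole 3-chlorophenyl leaves and a 2-methylphenyl enters. Among the compounds with values here, since the only known change at this place, a number 24 percentage points lower from compound 1 to compound 2 (beyond the scatter), lowered the number, a similar direction is expected, though with wide uncertainty. Compound 3 is therefore expected to give about 35%, within 10% to 60%, which means an estimated step of a number 14 percentage points lower from compound 1 to compound 3 (beyond the scatter).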

Compound 3, a percentage reported as inhibition, at one concentration (the size of the read-out at that concentration, not a potency): 33%
Compound 3: middle estimate off by 2 percentage points, on the high side; measured number inside the range.
By their numbers in this assay, from the lowest: compounds 2 and 3 (each within the scatter of the next); then compound 1.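

The step of a number 16 percentage points lower from compound 1 to compound 3 (beyond the scatter) shows that the drop at this position is not tied to the trifluoromethyl group. A second replacement of the 3-chlorophenyl, this one a 2-methylphenyl with the same count of heavy atoms and likewise no hydrogen-bond donors, acceptors or net charge, also lowers the number in this assay, leaving compound 1 above both other compounds, while compound 2 and compound 3 lie within the scatter of each other. Nothing measured on these compounds accounts for the fall.

This step alters both the substituent and where it sits on the phenyl, and the compounds shown cannot say which of the two goes with the lower number. Also open is how a plain phenyl, or a fluoro, methoxy or amine on the phenyl, would read in this assay, and whether compound 1 would keep its place among these aryl groups with a longer chain in place of the pentyl group.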